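The compounds below may be only part of what the source reports. "The series", "measured", "known", "first", "only" and "open" are said of these compounds alone.

Two related compounds have been tested so far in a functional assay on HCC827 cells (Homo sapiens) for cytotoxicity, read by MTT assay, with a stated time of 72 h; a higher number here means a weaker inhibitor, a lower number a stronger inhibitor. Compound 1 `CN1CCN(c2ccc(Nc3ncc4nc(Nc5ccccc5)n(C5CCCCC5)c4n3)cc2)CC1` gives < 0.01 nM, which is a limit of the assay and not a number. For the measured compounds named here, compound 2 `CC1CCN(c2ccc(Nc3ncc4nc(Nc5ccccc5)n(C5CCCC5)c4n3)cc2)CC1` gives 32 nM, the only true number available, so it serves as the single firm reference point for what follows.

Compound 3 `OCCNc1ccc(Nc2ncc3nc(Nc4ccccc4)n(C4CCCC4)c3n2)cc1` keeps the core of compound 2 and changes one group: (2-hydroxyethyl)amino in place of 4-methylpiperidin-1-yl on an aromatic carbon. The swap sits on a six-membered aromatic ring of carbon only, para to a large group, and an open chain with no ring replaces a ring-bearing substituent. Going by the values given here, no measured pair of compounds differs by a single change, so no earlier step can serve as a guide. The expectation therefore starts from compound 2 at 32 nM and remains a cautious judgement. A moderate loss of strength is expected, meaning a higher number in this assay, and the estimated change is a 3.1-fold higher number from compound 2 to compound 3 (0.49 log units; beyond the scatter). The estimated value for compound 3 is 100 nM, with an expected range from 10 nM to 1000 nM.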

Compound 3, half-maximal inhibitory concentration: 2.8 nM
Compound 3: the middle estimate sits 36-fold (1.55 log units) above what was measured; measured number below the stated range.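

Swapping the ring-bearing 4-methylpiperidin-1-yl for the open-chain (2-hydroxyethyl)amino, on an aromatic carbon para to a large group, gives in this assay an 11-fold lower number from compound 2 to compound 3 (1.06 log units; beyond the scatter), the first step in this set that can be read from a single change. At this position, then, a ring is not needed for strong activity in these cells, and a smaller group with no ring and more hydrogen-bond donors and acceptors is clearly better tolerated, although this one step cannot say which of these differences matters. Compound 1 stands at a limit and not a number, which shows that the assay can report far smaller values than a low single-digit reading: the limit of < 0.01 nM in this assay, at which 1 of the 3 values shown sits.

On these data alone, what remains open is what the hydroxyl itself contributes, since an ethylamino group would keep the open chain without that oxygen, while a longer chain such as 3-hydroxypropylamino would test how much the chain length counts. As far as these compounds go, it is also open whether the same swap would have a similar effect with the cyclohexyl group of compound 1 in place of the cyclopentyl group.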